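A few compounds are considered here, and "the series" means these few. Any claim that something is new, unique, unknown or untested is made for them only; others in the source may bear on it.

Measured compounds:
compound 1 `N#CC1=C(N)N(c2ccc(S(N)(=O)=O)cc2)C2=C(C(=O)CCC2)C1c1ccc(Cl)cc1Cl`, 65%
compound 2 `N#CC1=C(NC(=S)Nc2ccc(Br)cc2)N(c2ccc(S(N)(=O)=O)cc2)C2=C(C(=O)CCC2)C1c1ccc(Cl)cc1Cl`, 90%
compound 3 `N#CC1=C(NC(N)=O)N(c2ccc(S(N)(=O)=O)cc2)C2=C(C(=O)CCC2)C1c1ccc(Cl)cc1Cl`, 40%

In a functional assay on Ehrlich cells (Mus musculus) for cytotoxicity, read by trypan blue exclusion, with a stated time of 2 h, tested at 50 ug/mL (on this read-out higher numbers stand for a stronger effect at the one concentration tested and lower numbers for a weaker effect), compound 3 gives 40%, the lowest of the three numbers, with compound 1 nearest and compound 2 furthest. Compound 4 `N#CC1=C(N2C(=O)CCC2=O)N(c2ccc(S(N)(=O)=O)cc2)C2=C(C(=O)CCC2)C1c1ccc(Cl)cc1Cl` is not yet measured; it differs from compound 3 by 2,5-dioxopyrrolidin-1-yl in place of ureido on a double-bonded ring carbon.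

Among the measured compounds shown here, the steps that bear on this change are the two involving the ureido group. The step of a number 25 percentage points lower from compound 1 to compound 3 (beyond the scatter) was modest, and the step of a number 50 percentage points lower from compound 2 to compound 3 (beyond the scatter) was large, so the ureido compound sits low in this assay. The other step, a number 25 percentage points higher from compound 1 to compound 2 (beyond the scatter), shows that a larger substituent with a ring on the amine nitrogen carried the highest number in the series. The 2,5-dioxopyrrolidin-1-yl group is likewise larger than ureido and carries a ring, though it is not an aromatic one and its effect is not directly measured. A step upward is therefore expected for compound 4, estimated as a number 18 percentage points higher from compound 3 to compound 4 (beyond the scatter), modest rather than large. Compound 4 is estimated at 58%, within 38% to 78%.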

Compound 4, a percentage reported as activity, at one concentration (the size of the read-out at that concentration, not a potency): 70%
For compound 4 the middle estimate is 12 percentage points below the measured one; the range from low to high includes it.
By their numbers in this assay, from the lowest: compound 3; then compounds 1 and 4 (each within the scatter of the next); then compound 2.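

In this assay, 2,5-dioxopyrrolidin-1-yl in place of ureido on the double-bonded ring carbon gives a number 30 percentage points higher from compound 3 to compound 4 (beyond the scatter), so a high number at this position does not depend on an aromatic ring in the substituent or on hydrogen-bond donors in it. Set against the plain amino group, the same change gives a number 5 percentage points higher from compound 1 to compound 4 (within the scatter), while the group of compound 2, with its six-membered aromatic ring, stays on top, with a number 20 percentage points lower from compound 2 to compound 4 (beyond the scatter). Nothing available gives a reason for these steps.

The compounds shown leave open whether the ring or the two carbonyls of 2,5-dioxopyrrolidin-1-yl accounts for the distance from ureido, a question that an open-chain acetylamino group at this carbon would help to separate. Phthalimido at the same carbon would test whether an aromatic ring fused to the imide moves the number toward that of compound 2.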